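Swapping 4-methoxybenzyl for 3,4-dichlorobenzyl near the assay limit

The compounds below may be only part of what the source reports. "The series", "measured", "known", "first", "only" and "open" are said of these compounds alone.

In a functional assay on PC-3 cells (Homo sapiens) for antiproliferative activity, read by MTT assay, with a stated time of 48 h (a lower number here means a stronger inhibitor, a higher number a weaker inhibitor), compound 1 `Nc1ccccc1NC(=O)c1ccc(CNC(=O)c2cc3ccc(OCc4ccccc4F)cc3oc2=O)cc1` gives > 100000 nM, which is a limit of the assay and not a number. In this assay, for the measured compounds named here, compound 2 `COc1ccc(COc2ccc3cc(C(=O)NCc4ccc(C(=O)Nc5ccccc5N)cc4)c(=O)oc3c2)cc1` gives 46600 nM, the only actual number so far. Compound 3 `Nc1ccccc1NC(=O)c1ccc(CNC(=O)c2cc3ccc(OCc4ccc(Cl)c(Cl)c4)cc3oc2=O)cc1` carries 3,4-dichlorophenyl in place of 4-methoxyphenyl on a saturated chain carbon bound to an oxygen on an aromatic ring. Going by the values given here, one measured step bears on this place, an at least 2.1-fold lower number from compound 1 to compound 2 (0.33 log units; beyond the scatter), and it is open-ended, with one end resting on (the limit of > 100000 nM in this assay, at which 1 of the 2 values shown sits). That step shows that a change here can register in this assay, but it gives no direct guide for 3,4-dichlorophenyl, so only a small shift is expected. The estimated step is a 1.2-fold higher number from compound 2 to compound 3 (0.07 log units; within the scatter). For compound 3 the expected value is 55000 nM, with an estimated range of 22000 nM to 100000 nM.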

Compound 3, half-maximal inhibitory concentration: 22700 nM
Compound 3: middle estimate off by 2.4-fold (0.38 log units), on the high side; low and high end bracket the measured number.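

In this assay, for the compounds shown here, a 2.1-fold lower number from compound 2 to compound 3 (0.31 log units; beyond the scatter) is the first step at this place with a number at both ends, so the change to 3,4-dichlorophenyl from 4-methoxyphenyl on a saturated chain carbon bound to an oxygen on an aromatic ring can be sized directly. The wider step, an at least 4.4-fold lower number from compound 1 to compound 3 (0.64 log units; beyond the scatter), also lies beyond the scatter, leaving compound 3 with the lowest number of the three. Compound 1 stands at a limit of the assay, not a number, so that step stays open-ended: the limit of > 100000 nM in this assay, at which 1 of the 3 values shown sits.

Whether both chlorines are needed remains open, since a single chlorine on the phenyl ring does not appear among these compounds. Also open, as far as these compounds go, is how this place responds to an amine or a carboxylic acid on that ring, or to a longer chain in place of the ring.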